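Furan for thiophene on the diamino nucleoside core

A few compounds are considered here, and "the series" means these few. Any claim that something is new, unique, unknown or untested is made for them only; others in the source may bear on it.

Compound 1 `Nc1nc(N)c2c(-c3ccsc3)cn([C@@H]3O[C@H](CO)[C@@H](O)[C@H]3O)c2n1` carries thiophen-3-yl on the shared core. In a functional assay on A549 cells (Homo sapiens), read by MTT assay, with a stated time of 72 h (a higher number here means a weaker inhibitor, a lower number a stronger inhibitor), compound 1 reaches only a limit of the assay, > 100000 nM, which is the limit of > 100000 nM in this assay, at which 1 of the 2 values shown sits. Compound 2 `C#Cc1cn([C@@H]2O[C@H](CO)[C@@H](O)[C@H]2O)c2ncnc(OC)c12`, built on a different core, gives in this assay a value of 8160 nM. Compound 3 `Nc1nc(N)c2c(-c3ccoc3)cn([C@@H]3O[C@H](CO)[C@@H](O)[C@H]3O)c2n1` differs from compound 1 in one place: furan-3-yl in place of thiophen-3-yl on an aromatic carbon. No measured step joins any two of these compounds, so the size of this change is not known from the data. Compound 3 is expected to stay close to compound 1, a step of a number no higher from compound 1 to compound 3 (the limit leaves the size open), none beyond the scatter. For compound 3 the estimate is 100000 nM, within 30000 nM to 300000 nM, with a limit again likely.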

Compound 3, half-maximal inhibitory concentration: > 20000 nM
Compound 3 ended at the assay's limit (the forecaster's own chance of this, stated with the estimate: 75%); the middle value is on the limit's open side.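

Compound 1 gives only a limit in this assay, > 100000 nM. Going by these compounds alone, compound 3 also gives only a limit, > 20000 nM, and no step from it to compound 1 can be read. Going by these compounds, whether furan-3-yl or thiophen-3-yl gives the stronger inhibitor on the shared core stays open.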